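From 2-methoxyphenyl to 3-methoxyphenyl in compound 4

The compounds below may be only part of what the source reports. "The series", "measured", "known", "first", "only" and "open" are said of these compounds alone.

Measured so far in a functional assay on HT-29 cells (Homo sapiens) for antiproliferative activity, read by sulforhodamine B assay, with a stated time of 48 h; a higher number here means a weaker inhibitor, a lower number a stronger inhibitor:
- compound 1 `COc1ccccc1OS(=O)(=O)c1ccc(N2CCN(C)C2=O)cc1` gives 26000 nM as a number
- compound 2 `COc1cccc(OS(=O)(=O)c2ccc(N3CCN(C)C3=O)cc2)c1` gives 2500 nM as a number
- compound 3 `CCN1CCN(c2ccc(S(=O)(=O)Oc3ccccc3OC)cc2)C1=O` gives > 100000 nM as a limit

Compound 3 sits at the limit of > 100000 nM in this assay, at which 1 of the 3 values shown sits, and has no number.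

Compound 4 `CCN1CCN(c2ccc(S(=O)(=O)Oc3cccc(OC)c3)cc2)C1=O` is not yet measured. It carries 3-methoxyphenyl in place of 2-methoxyphenyl on an oxygen whose other neighbour is the sulfonyl sulfur (3-methoxyphenyl in place of 2-methoxyphenyl on an oxygen).

Within the data shown here, two measured steps bear on this. The same exchange gave a 10-fold lower number from compound 1 to compound 2 (1.02 log units; beyond the scatter), a large step beyond the scatter. The methyl in place of hydrogen on the saturated chain carbon gave an at least 3.8-fold higher number from compound 1 to compound 3 (0.58 log units; beyond the scatter), at least a modest step. Applied to compound 2 (2500 nM), that second step points to a higher number for compound 4. The first step points to a large fall from the limit of compound 3.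

As far as these compounds go, a large step to a lower number is therefore expected in this assay, though its exact size stays open. The step expected is an at least 8.3-fold lower number from compound 3 to compound 4 (0.92 log units; beyond the scatter) in this assay by this estimate. Compound 4 is estimated at 12000 nM, with an expected range from 3000 nM to 50000 nM in this assay.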

Compound 4, half-maximal inhibitory concentration: 22000 nM
The estimate for compound 4 lay 1.8-fold (0.26 log units) below the measured number, and the stated range covers the measured number.
By their numbers in this assay, from the lowest: compound 2; then compounds 4 and 1 (each within the scatter of the next). At a limit, above all of these: compound 3.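

In this assay, 3-methoxyphenyl in place of 2-methoxyphenyl on the oxygen also lowers the number on a second core, with an at least 4.5-fold lower number from compound 3 to compound 4 (0.65 log units; beyond the scatter), so this gain is no longer tied to the core of compound 1: the same change on two cores in this assay, a 10-fold lower number (1.02 log units; beyond the scatter) from compound 1 to compound 2 and an at least 4.5-fold lower number (0.65 log units; beyond the scatter) from compound 3 to compound 4; the limit leaves it open whether they differ

The added methyl on the saturated chain carbon now has a step of definite size, an 8.8-fold higher number from compound 2 to compound 4 (0.94 log units; beyond the scatter), and the loss it brings holds with 3-methoxyphenyl as well as with 2-methoxyphenyl: the same change on two cores in this assay, an at least 3.8-fold higher number (0.58 log units; beyond the scatter) from compound 1 to compound 3 and an 8.8-fold higher number (0.94 log units; beyond the scatter) from compound 2 to compound 4; the limit leaves it open whether they differ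

Whether either change has the same size on both cores stays open, because compound 3 has no number: the limit of > 100000 nM in this assay, at which 1 of the 4 values shown sits.

Also open, as far as these compounds go, is how this assay would respond to an amine or a carboxylic acid in place of the methoxy group of 3-methoxyphenyl, or to a longer chain on the saturated chain carbon.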